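A few compounds are considered here, and "the series" means these few. Any claim that something is new, unique, unknown or untested is made for them only; others in the source may bear on it.

Of the compounds shown here, three built on one shared core have been tested in a functional assay on HT-29 cells (Homo sapiens) for inhibition, read by sulforhodamine B assay, with a stated time of 48 h; on this read-out higher numbers stand for weaker inhibition of growth and lower numbers for stronger inhibition of growth. Compound 2 `COc1ccc(CNc2nc3cc(N)cc(N)c3nc2-c2ccccc2)cc1OC` gives 1860 nM in this assay, the lowest of the two numbers in hand. Compound 3 `CCOC(=O)[C@H](CCC(=O)O)NC(=O)c1ccc(Sc2nc3cc(N)cc(N)c3nc2-c2ccccc2)cc1` gives 9550 nM, a value that lies beyond the scatter away from that of compound 2. For compound 1 `CCOC(=O)[C@H](CCC(=O)O)NC(=O)c1ccc(CNc2nc3cc(N)cc(N)c3nc2-c2ccccc2)cc1` only a limit was reported, < 100000 nM, so it is not a number. Compound 4 `COc1ccc(CNc2nc3cc(N)cc(N)c3nc2-c2ccccc2)cc1` differs from compound 2 in one place: hydrogen in place of methoxy on an aromatic carbon. For the measured compounds named here, no measured pair shows this same change, so the size of the step is open; the loss of one methoxy group is expected to move the number little, if at all, beyond the scatter. Compound 4 is therefore estimated at 2500 nM in this assay, with a range from 800 nM to 8000 nM, meaning an expected step of a 1.3-fold higher number from compound 2 to compound 4 (0.13 log units; within the scatter).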

Compound 4, concentration for 50% growth inhibition: 24500 nM
For compound 4 the middle estimate is 9.8-fold (0.99 log units) below the measured one; the measured number lies above the stated range.
By their numbers in this assay, from the lowest: compound 2; then compound 3; then compound 4.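

For the compounds shown here, removing one methoxy group, which turns 3,4-dimethoxyphenyl into 4-methoxyphenyl, gives a 13-fold higher number from compound 2 to compound 4 (1.12 log units; beyond the scatter) in this assay and is the first single-place step read in this set. This position, ortho to a methoxy group and meta to a large group, therefore matters for growth inhibition, and hydrogen does not stand in for methoxy there. Nothing in the data shown accounts for the size of this step. From the compounds shown here alone, it remains open whether a hydroxyl group, a fluorine atom or an amine at this position would keep the number of compound 2. Also open, going by these compounds, is whether removing the other methoxy group would give a similar step.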